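Replacing the hydroxyamino urea in compound 3 with a bicyclic acyl group

The source may hold more compounds than are shown below. What is called first, only, known or untested is meant among the compounds shown, and "the series" means these compounds.

Measured compounds:
compound 1 `CCC(C)C(NC(=O)n1nnc2ccccc21)C(=O)NC(c1ccccc1)c1ccccc1` — 60000 nM
compound 2 `CCC(C)C(NC(=O)n1nnc2ccccc21)C(=O)NC1CCCCC1` — 63900 nM
compound 3 `CCC(C)C(NC(=O)NO)C(=O)NCc1ccccc1` — > 100000 nM

Three compounds have been run in a functional assay on HeLa cells (Homo sapiens) for inhibition; on this read-out higher numbers stand for weaker inhibition and lower numbers for stronger inhibition. Compound 1 gives 60000 nM and compound 2 gives 63900 nM in this assay; these two values lie within the scatter of each other, so neither is called stronger. For compound 3 this assay returns only a limit, > 100000 nM, which is not a number and marks where 1 of the 3 values shown sit (the limit of > 100000 nM in this assay, at which 1 of the 3 values shown sits). Compound 3 therefore stands at the weak end of what has been recorded, without a measured value of its own.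

Compound 4 `CCC(C)C(NC(=O)n1nnc2ccccc21)C(=O)NCc1ccccc1` has not yet been measured. It differs from compound 3 in one place: a group of 9 heavy atoms (6 carbon, 3 nitrogen; one five-membered aromatic ring with 3 hetero atoms, one six-membered aromatic ring of carbon only) in place of a group of 2 heavy atoms (1 nitrogen, 1 oxygen; no ring), on a carbonyl carbon. The group that enters is the same acyl group that compounds 1 and 2 carry on their amino nitrogen, while the amide substituent of compound 4 stays as in compound 3.

Since compound 3 only gives a limit, the step to compound 4 cannot be computed from measurements. Compound 4 is expected to behave like compound 1, which gives 60000 nM, and like compound 2, which gives 63900 nM, rather than like compound 3. The expected step is estimated as an at least 1.4-fold lower number from compound 3 to compound 4 (0.15 log units; that floor lies within the scatter), in the direction of stronger inhibition. Compound 4 is therefore estimated at 70000 nM, with a range from 30000 nM to 160000 nM.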

Compound 4, half-maximal inhibitory concentration: >= 100000 nM
Compound 4 gave a limit, no number; the forecaster's own chance of this, stated with the estimate: 30%; middle value at least 1.4-fold (0.15 log units) away from the limit.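

In this assay compound 4 gives only a limit, >= 100000 nM, so carrying the acyl group of compound 1 and compound 2 on the carbonyl carbon did not by itself yield a measured value here, and the step from compound 3, with limits at both ends, cannot be read. On the amide-type nitrogen, benzyl in place of cyclohexyl is an at least 1.5-fold higher number from compound 2 to compound 4 (0.19 log units; that floor lies within the scatter), and hydrogen in place of phenyl on the saturated chain carbon is an at least 1.6-fold higher number from compound 1 to compound 4 (0.22 log units; that floor lies within the scatter). Both floors lie within the scatter, so compound 4 cannot be called weaker than compound 1 or compound 2, although only these two of the three compounds with this acyl group have a measured value.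

The compounds shown leave open whether the acyl group and the hydroxyamino group differ at all in this assay, and how far above its limit compound 4 really lies. They also leave open what a longer chain such as phenethyl on the amide-type nitrogen, or a carboxylic acid on the benzyl ring, would do to the read-out.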